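Swapping a thioester tail for a phenyl ketone

The compounds below may be only part of what the source reports. "The series", "measured", "known", "first", "only" and "open" are said of these compounds alone.

Of the compounds shown here, three sharing one core have been measured in a physicochemical assay for lipophilicity; on this read-out higher numbers stand for higher lipophilicity and lower numbers for lower lipophilicity. Compound 1 `COC(=O)/C=C(C)/C=C/CC(C)CCCC(C)C` gives 6.2. Compound 2 `CC(/C=C/CC(C)CCCC(C)C)=C\C(=O)OCc1ccccc1` gives 7.87, and compound 3 `CCSC(=O)/C=C(C)/C=C/CC(C)CCCC(C)C` gives 7.98, the highest of the three numbers, though it sits within the scatter of compound 2 and clearly beyond that of compound 1.

Compound 4 `CC(/C=C/CC(C)CCCC(C)C)=C\C(=O)c1ccccc1` has not yet been measured. It differs from compound 3 in one place: phenyl in place of ethylsulfanyl on a carbonyl carbon.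

Among the compounds with values here, two measured steps bear on this change. Putting phenyl in place of hydrogen on a saturated chain carbon bound to an oxygen next to a carbonyl group gave a number 1.67 log units higher from compound 1 to compound 2 (beyond the scatter), and putting ethylsulfanyl in place of benzyloxy on a carbonyl carbon gave a number 0.11 log units higher from compound 2 to compound 3 (within the scatter). Compound 4 carries the phenyl of compound 2 but lacks both the ethylsulfanyl of compound 3 and the oxygen link of compound 2, so no large shift is expected. Compound 4 is estimated at 7.8, in the range 7.2 to 8.4, which means an expected step of a number 0.18 log units lower from compound 3 to compound 4 (within the scatter).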

Compound 4, partition coefficient: 7.26
Estimate against measurement, compound 4: 0.54 log units above, and the stated range covers the measured number.
By their numbers in this assay, from the lowest: compound 1; then compound 4; then compounds 2 and 3 (each within the scatter of the next).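

Ethylsulfanyl and benzyloxy on this carbonyl carbon could not be told apart in this assay, but phenyl at the same place stands clear of both, with a number 0.72 log units lower from compound 3 to compound 4 (beyond the scatter) and with a number 0.61 log units lower from compound 2 to compound 4 (beyond the scatter). So a phenyl bound directly to the carbonyl carbon does not repeat the result of the phenyl carried within benzyloxy, yet it still stands well apart from methoxy, with a number 1.06 log units higher from compound 1 to compound 4 (beyond the scatter). Nothing shown here explains these steps.

Only four groups on this carbonyl carbon are shown, so it stays open where an amine, a hydroxyl or a longer chain such as butoxy would fall. From the compounds shown here alone, it is also open whether a fluorine on the phenyl of compound 4 would move the number at all.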